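The compounds below may be only part of what the source reports. "The series", "measured", "known", "first", "only" and "open" are said of these compounds alone.

In an ADME assay on WI-38 cells (Homo sapiens) for cytotoxicity, read by MTT assay, with a stated time of 72 h (a lower number here means a stronger inhibitor, a higher number a weaker inhibitor), compound 1 `O=C(CCc1cccc2c1B(O)OC2)NC1CCCCC1` gives > 100000 nM, which is a limit of the assay and not a number. Going by the values given here, compound 2 `O=C(CCc1cccc2c1B(O)OC2)Nc1ccc(Br)cc1` gives 42000 nM, the only true number so far. Putting 4-bromophenyl in place of cyclohexyl on the amide-type nitrogen gives an at least 2.3-fold lower number from compound 1 to compound 2 (0.37 log units; beyond the scatter), a step beyond the scatter.

Compound 3 `CC(C)(C)c1ccc(NC(=O)CCc2cccc3c2B(O)OC3)cc1` has tert-butyl in place of bromo on an aromatic carbon. Among the compounds with values here, the one measured step, an at least 2.3-fold lower number from compound 1 to compound 2 (0.37 log units; beyond the scatter), bears on this only loosely, since it replaced the whole group on the nitrogen, whereas here only the group on the aromatic ring changes. No step beyond the scatter is therefore expected, with compound 2 at 42000 nM as the best guide. The expected change is a 1.2-fold lower number from compound 2 to compound 3 (0.08 log units; within the scatter). For compound 3 the estimated value is 35000 nM, with an expected range from 14000 nM to 90000 nM.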

Compound 3, half-maximal inhibitory concentration: 55000 nM
Compound 3: the middle estimate sits 1.6-fold (0.20 log units) below what was measured; the measured number falls inside the stated range.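

Replacing bromo with tert-butyl gives a 1.3-fold higher number from compound 2 to compound 3 (0.12 log units; within the scatter) in this assay, so this pair cannot be told apart in this assay. Tert-butyl brings more heavy atoms than bromo, yet this change on an aromatic carbon, para to a large group, produces no readable shift, something the earlier step could not show, as it replaced the whole group on the nitrogen. Compound 1 stands at a limit of the assay and not at a number, so the only true numbers come from this one pair: the limit of > 100000 nM in this assay, at which 1 of the 3 values shown sits.

As far as these compounds go, whether an amine or a carboxylic acid at this place on the ring would move the number beyond the scatter stays open. So does whether the same swap would read alike with a longer chain leading to the carbonyl.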